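Swapping methyl for trifluoromethyl on the urea phenyl ring

The source may report more compounds than this note shows. Statements on the series, on what has been measured and on what is new or still open speak of the compounds shown alone.

Compound 3 `COc1cc2ncnc(NCc3cccc(NC(=O)Nc4ccc(C)cc4)c3)c2cc1OC` was tested in a functional assay on HepG2 cells (Homo sapiens) for antiproliferative activity, read by MTT assay; a lower number here means a stronger inhibitor, a higher number a weaker inhibitor. In this assay compound 3 gives > 50000 nM, which is a limit of the assay rather than a number. Compound 1 `Cc1ccccc1NC(=O)Nc1cccc(CNc2ncnc3ccccc23)c1` gives > 50000 nM, also a limit. Compound 2 `O=C(Nc1ccc([N+](=O)[O-])cc1)Nc1cccc(CNc2ncnc3ccccc23)c1` gives 24600 nM. Compound 4 `COc1cc2ncnc(NCc3cccc(NC(=O)Nc4cccc(C(F)(F)F)c4)c3)c2cc1OC` differs from compound 3 in one place: 3-(trifluoromethyl)phenyl in place of 4-methylphenyl on an amide-type nitrogen. Within the data shown here, the only measured step on the same amide-type nitrogen is an at least 2.0-fold lower number from compound 1 to compound 2 (0.30 log units; that floor lies within the scatter), a change whose floor lies within the scatter. Given (the limit of > 50000 nM in this assay, at which 2 of the 3 values shown sit), compound 4 is expected to remain weak, and the step of an at least 1.4-fold lower number from compound 3 to compound 4 (0.15 log units; that floor lies within the scatter) is the expectation here. Compound 4 is therefore estimated at 35000 nM, within a range from 8000 nM to 150000 nM.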

Compound 4, half-maximal inhibitory concentration: 34200 nM
The estimate for compound 4 lay 1.0-fold (0.01 log units) above the measured number; the range from low to high includes it.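

Read in this assay, the swap gives an at least 1.4-fold lower number from compound 3 to compound 4 (0.16 log units; that floor lies within the scatter). With the core of compound 3, this position can therefore yield a true number, but nothing shows a real gain in strength. The size of the step remains unknown because compound 3 sits at a limit of the assay: the limit of > 50000 nM in this assay, at which 2 of the 4 values shown sit.

The swap changes both the group and its place on the phenyl ring, and these compounds cannot separate the two. As far as these compounds go, whether an amine or a carboxylic acid on that ring would give a clearly stronger inhibitor stays open.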